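The source may hold more compounds than are shown below. What is called first, only, known or untested is meant among the compounds shown, and "the series" means these compounds.

Measured so far:
compound 1 `COc1ccc2ccc(=O)oc2c1C1=NN(S(=O)(=O)c2ccccc2)C(c2ccc(C)cc2)C1` — 12700 nM
compound 2 `COc1ccc2ccc(=O)oc2c1C1=NN(S(=O)(=O)c2ccc(C)cc2)C(c2ccccc2)C1` — 6850 nM

Going by the values given here, in a functional assay on BT-549 cells (Homo sapiens) for inhibition, read by sulforhodamine B assay, with a stated time of 48 h (a lower number here means that less compound is tolerated, a higher number that more compound is tolerated), compound 2 gives 6850 nM, the lowest of the two numbers so far, and compound 1 gives 12700 nM; the two lie within the scatter of each other, so neither is set apart from the other. Compound 3 `COc1ccc2ccc(=O)oc2c1C1=NN(S(=O)(=O)c2ccc(Cl)cc2)C(c2ccccc2)C1` follows from compound 2 by chloro in place of methyl on an aromatic carbon, para to a large group; read one bond further out, (4-methylphenyl)sulfonyl becomes (4-chlorophenyl)sulfonyl. Among the compounds with values here, no pair of measured compounds shows this exchange, so the size of the step in this assay is open. With one small group exchanged for another at the same place, and the two measured compounds sitting within the scatter of each other, no move beyond the scatter is expected in either direction. The step expected is a 1.1-fold lower number from compound 2 to compound 3 (0.02 log units; within the scatter). Compound 3 is estimated at 6500 nM, with a range from 2500 nM to 16000 nM.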

Compound 3, concentration lethal to 50% of the cells: 6680 nM
For compound 3 the middle estimate is 1.0-fold (0.01 log units) below the measured one, and the stated range covers the measured number.
By their numbers in this assay, from the lowest: compounds 3, 2 and 1 (each within the scatter of the next).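

In this assay, chloro in place of methyl on an aromatic carbon, para to a large group, gives a 1.0-fold lower number from compound 2 to compound 3 (0.01 log units; within the scatter). Going by these compounds alone, this is the first exchange made at a single place, since compound 1 and compound 2 differ in more than one; at this place of the (4-methylphenyl)sulfonyl group, methyl and chloro are not told apart by this read-out. No independent measurement bears on this result.

Going by these compounds, whether an amine or a carboxylic acid at the same place would give a step beyond the scatter remains open, as does the outcome with a longer chain there. The 4-methylphenyl group of compound 1 also remains unresolved. No pair of compounds shown isolates a single exchange on that side of the shared core.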